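Moving the fluorine around the sulfonyl-linked phenyl ring

This account rests on a few compounds, and the source may have more. Where it says the series, first, only, none or still open, it means among the compounds named here.

In a functional assay (Cavia porcellus) with sulfonylurea receptors; K-ATP channels (Homo sapiens) as the target (on this read-out lower numbers stand for stronger inhibition and higher numbers for weaker inhibition), two compounds of this series have been tested so far. Compound 1 `CC(O)(C(=O)Nc1cccc(S(=O)(=O)c2ccccc2)c1)C(F)(F)F` gave only a limit of the assay, reported as > 30000 nM, and no number. For the measured compounds named here, compound 2 `CC(O)(C(=O)Nc1ccc(S(=O)(=O)c2ccccc2F)cc1)C(F)(F)F` is the one compound with a measured number, giving 1300 nM in this assay. Where compound 2 stands is thus set by this single value, with the limit of > 30000 nM in this assay, at which 1 of the 2 values shown sits, being the only other point of reference.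

The step to compound 3 `CC(O)(C(=O)Nc1ccc(S(=O)(=O)c2cccc(F)c2)cc1)C(F)(F)F` is a rearrangement rather than an exchange of matter: the two compounds share the same atoms, joined differently, with 3-fluorophenyl in place of 2-fluorophenyl on a sulfonyl sulfur. Going by the values given here, no measured pair in this set shows what such a change does, so the size of the step cannot be read from anything already in hand. The change keeps every atom and alters only the fluorophenyl group on the sulfonyl sulfur, and the step is expected to be small, quite possibly none beyond the usual scatter, with no firm direction. Compound 3 is therefore estimated to give 1500 nM in this assay, with a plausible range from 500 nM to 5000 nM. The expected step is a 1.2-fold higher number from compound 2 to compound 3 (0.06 log units; within the scatter), which is estimated to stay within the scatter.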

Compound 3, half-maximal inhibitory concentration: 3400 nM
Estimate against measurement, compound 3: 2.3-fold (0.36 log units) below; measured number inside the range.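

The position of the fluorine on this ring turns out to matter: with every atom kept, 3-fluorophenyl in place of 2-fluorophenyl on a sulfonyl sulfur brings a 2.6-fold higher number from compound 2 to compound 3 (0.42 log units; beyond the scatter) in this assay. For the compounds shown here, this is the first measured pair, and it shows that this place responds to a rearrangement alone, with compound 2 holding the lower number by a modest margin. Compound 1 carries only a limit of the assay, so it offers no number against which this step could be sized: the limit of > 30000 nM in this assay, at which 1 of the 3 values shown sits.

The two numbers do not say why moving the fluorine has this effect, nor whether a step of this size would also appear with a chlorine, a methoxy group or a nitrile in place of the fluorine on this ring. On these data alone, how a plain phenyl on the sulfonyl sulfur of the same core would compare with compound 2 and compound 3 also remains open, and with it what the fluorine itself contributes.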